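Swapping a Ring Guanidine for a Carbamate Cap

A few compounds are considered here, and "the series" means these few. Any claim that something is new, unique, unknown or untested is made for them only; others in the source may bear on it.

In an assay on isolated protein for binding affinity to Gonadotropin-releasing hormone receptor (Rattus norvegicus) (a lower number here means a stronger inhibitor, a higher number a weaker inhibitor), compound 1 `CCOC(=O)[C@H]1CC[C@H](CNC(=O)c2ccc(Cc3cc4c(cc3C)C(C)(C)CCC4(C)C)o2)CC1` gives 2730 nM. In this assay compound 2 `Cc1cc2c(cc1Cc1ccc(C(=O)NCC3CCCC(CN)C3)o1)C(C)(C)CCC2(C)C` gives 890 nM. In this assay compound 3 `Cc1cc2c(cc1Cc1ccc(C(=O)NCC3CCN(C(=N)N)CC3)o1)C(C)(C)CCC2(C)C` gives 2040 nM.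

Compound 3 holds the second highest of the three numbers: it sits within the scatter of compound 1, while the change from compound 2 to compound 3 is a modest step, a 2.3-fold higher number from compound 2 to compound 3 (0.36 log units; beyond the scatter). Compound 4 `Cc1cc2c(cc1Cc1ccc(C(=O)NCC3CCN(C(=O)OC(C)(C)C)CC3)o1)C(C)(C)CCC2(C)C` differs from compound 3 by a group of 7 heavy atoms (5 carbon, 2 oxygen; no ring) in place of a group of 3 heavy atoms (1 carbon, 2 nitrogen; no ring), on an amine nitrogen in a ring. Within the data shown here, the steps that bear on this change are a 1.3-fold lower number from compound 1 to compound 3 (0.13 log units; within the scatter) and a 2.3-fold higher number from compound 2 to compound 3 (0.36 log units; beyond the scatter); only the aminomethyl group of compound 2 gave a clearly lower number. Compound 4 is therefore expected to move little, with a 1.2-fold higher number from compound 3 to compound 4 (0.09 log units; within the scatter) inside the scatter. For compound 4 in this assay the estimate is 2500 nM, between 800 nM and 8000 nM.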

Compound 4, inhibition constant: 3260 nM
The estimate for compound 4 lay 1.3-fold (0.12 log units) below the measured number; the range from low to high includes it.
By their numbers in this assay, from the lowest: compound 2; then compounds 3, 1 and 4 (each within the scatter of the next).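

On the amine nitrogen in the ring, tert-butoxycarbonyl in place of the group of 3 heavy atoms gave a 1.6-fold higher number from compound 3 to compound 4 (0.20 log units; within the scatter) in this assay. At this position, then, a larger group with 0 hydrogen-bond donors and one with 2 hydrogen-bond donors could not be told apart in this measurement. Nothing available explains this result.

The compounds shown leave open how a free amine or a simple acetyl group on this ring nitrogen would read in this assay.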